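Swapping Chloro for Nitro on the Hydrazone Aryl Ring

The compounds below may be only part of what the source reports. "The series", "measured", "known", "first", "only" and "open" are said of these compounds alone.

Compound 1 `CCCSc1nc(N/N=C(\C)c2ccccc2O)c2nnn(Cc3ccc(Cl)cc3)c2n1` gives 11200 nM.
Compound 2 `CCCSc1nc(N/N=C/c2ccc(Cl)cc2)c2nnn(Cc3ccccc3)c2n1` gives > 64000 nM, which is a limit of the assay rather than a number.
Compound 3 `C#CCSc1nc(N/N=C/c2cc(OC)c(OC)c(OC)c2)c2nnn(Cc3ccccc3)c2n1` gives 6540 nM.

These three share one core and differ in the aryl group hanging from the hydrazone and in the groups on sulfur and on the ring nitrogen. They were tested in a functional assay on ECa-109 cells (Homo sapiens) for antiproliferative activity, read by MTT assay, with a stated time of 72 h; a lower number here means a stronger inhibitor, a higher number a weaker inhibitor. For the measured compounds named here, compound 2 stands apart: no number is known for it, only (the limit of > 64000 nM in this assay, at which 1 of the 3 values shown sits), so it is the one compound for which the assay reported no measurable inhibition.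

Compound 4 `CCCSc1nc(N/N=C/c2ccc([N+](=O)[O-])cc2)c2nnn(Cc3ccccc3)c2n1` has not yet been tested. It differs from compound 2 in a single place: nitro in place of chloro on an aromatic carbon. Going by the values given here, no pair of measured compounds differs in exactly this way, so nothing measured here tells how large such a change is. Compound 1 and compound 3 show that other aryl groups on this core do give measurable numbers in this assay. On that basis the step from compound 2 to compound 4 is expected to bring the value back into the measurable range, a change of an at least 2.1-fold lower number from compound 2 to compound 4 (0.32 log units; beyond the scatter), though a limit remains quite possible. Compound 4 is therefore estimated at 30000 nM, between 8000 nM and 120000 nM.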

Compound 4, half-maximal inhibitory concentration: 6640 nM
Compound 4: middle estimate off by 4.5-fold (0.65 log units), on the high side, and the stated range ends above it.
By their numbers in this assay, from the lowest: compounds 3, 4 and 1 (each within the scatter of the next). At a limit, above all of these: compound 2.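

In this assay, for the compounds shown here, the change from 4-chlorophenyl to 4-nitrophenyl is the only comparison here in which just one place differs, and it gives an at least 9.6-fold lower number from compound 2 to compound 4 (0.98 log units; beyond the scatter). This shows that the group on this aromatic carbon matters: with the rest of the molecule held the same, this one replacement turns a result with no number into a measurable value. The true size of the step cannot be fixed, because compound 2 has only a limit and not a number: the limit of > 64000 nM in this assay, at which 1 of the 4 values shown sits.

A single step cannot show whether the gain is specific to nitro or would come with other replacements for chloro, such as an amine or a carboxylic acid on the same carbon. It also leaves open whether the same swap would have a similar effect with other groups on sulfur and on the ring nitrogen.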